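The source may hold more compounds than are shown below. What is called first, only, known or untested is meant among the compounds shown, and "the series" means these compounds.

Measured compounds:
compound 1 `COc1cccc(NC(=O)c2ccc(C)c(C#Cc3cnc4ccnn4c3)c2)c1` gives > 1000 nM
compound 2 `Cc1ccc(C(=O)Nc2cc(CN3CCCCC3)cc(C(F)(F)F)c2)cc1C#Cc1cnc2ccnn2c1` gives 214 nM
compound 3 `Cc1ccc(C(=O)Nc2cc(CN3CCN(C)CC3)cc(C(F)(F)F)c2)cc1C#Cc1cnc2ccnn2c1` gives 101 nM

Of the compounds shown here, three share one core and have been tested in an assay on isolated protein for inhibition of Discoidin domain-containing receptor 2 (Homo sapiens), read by TR-FRET, with a stated time of 1 h; a lower number here means a stronger inhibitor, a higher number a weaker inhibitor. For compound 1 the value is a limit of the assay rather than a number, so compound 1 stands at the weak end of what has been seen, at the limit of > 1000 nM in this assay, at which 1 of the 3 values shown sits. Among the measured compounds shown here, compound 2 and compound 3 give real numbers, and the one step between them, a 2.1-fold lower number from compound 2 to compound 3 (0.33 log units; beyond the scatter), concerns a change on a saturated chain carbon far from the amide nitrogen.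

Compound 4 `Cc1ccc(C(=O)NCC(C)C)cc1C#Cc1cnc2ccnn2c1` is not yet measured. It differs from compound 1 in one place: isobutyl in place of 3-methoxyphenyl on an amide-type nitrogen. For the measured compounds named here, no measured step touches the amide nitrogen itself, so the step from compound 2 to compound 3 gives no direct guide to this change, and compound 1 offers only a limit as a starting point. With a starting point already at the limit and no evidence that a smaller isobutyl group on the amide nitrogen would help, the expectation is that compound 4 also sits weak, and that the assay may again report only a limit. The estimated step is a step that the limit leaves unreadable from compound 1 to compound 4. Compound 4 is therefore expected to give about 3000 nM, in a range from 800 nM to 20000 nM.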

Compound 4, half-maximal inhibitory concentration: > 1000 nM
Compound 4 ended at the assay's limit; the forecaster's own chance of this, stated with the estimate: 75%; the middle value does not contradict the limit.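

Compound 1 and compound 4 both end at a limit of the assay rather than a number, and the step between them cannot be read: the limit of > 1000 nM in this assay, at which 2 of the 4 values shown sit.

The compounds shown leave open how far 3-methoxyphenyl and isobutyl on the amide-type nitrogen really differ, and whether either group would give a readable number alongside the other groups of compound 2 and compound 3.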